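The compounds below may be only part of what the source reports. "The series", "measured", "known", "first", "only" and "open" are said of these compounds alone.

Compound 1 `CCc1ccc(C(=O)/C=C/C(=O)O)cc1`: 5530 nM
Compound 2 `CCc1cc(CC)c(C(=O)/C=C/C(=O)O)c(CC)c1`: 4010 nM
Compound 3 `O=C(O)/C=C/C(=O)c1cc(C2CCCCC2)ccc1C1CCCCC1`: 3320 nM

These values come from a functional assay on K562 cells (Homo sapiens) for inhibition, read by MTT assay, with a stated time of 72 h; on this read-out lower numbers stand for stronger inhibition and higher numbers for weaker inhibition. On this measure, compound 1 stands level with compound 2 and compound 3, since its value lies within the usual scatter of both.

Compound 4 `O=C(O)/C=C/C(=O)c1ccc(F)cc1` has not yet been measured. It differs from compound 1 at one place: fluoro in place of ethyl on an aromatic carbon. This puts fluoro in place of ethyl on an aromatic carbon.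

Among the compounds with values here, no measured pair shows this exact swap, so the evidence is indirect. Compound 2 at 4010 nM and compound 3 at 3320 nM carry other groups on the shared core, yet they stay within the scatter of compound 1. No change beyond the scatter is therefore expected. The expected step, a 1.0-fold lower number from compound 1 to compound 4 (0.00 log units; within the scatter), is within the scatter. For compound 4 the estimate is 5500 nM, with an expected range of 2800 nM to 11000 nM.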

Compound 4, half-maximal inhibitory concentration: 16900 nM
The estimate for compound 4 lay 3.1-fold (0.49 log units) below the measured number; the whole stated range lies below it.
By their numbers in this assay, from the lowest: compounds 3, 2 and 1 (each within the scatter of the next); then compound 4.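

In this assay, fluoro in place of ethyl on this aromatic carbon gives a 3.1-fold higher number from compound 1 to compound 4 (0.49 log units; beyond the scatter), so inhibition weakens. This shows that the group at this position can matter, which compound 1, compound 2 and compound 3 did not reveal, as their values all lie within the scatter of one another. No measurement shown here accounts for the step. From the compounds shown here alone, it remains open whether the weaker inhibition follows from losing ethyl or from gaining fluoro. Going by these compounds, how a methoxy group, an amine or a longer chain would behave at this position also remains open.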